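The source may hold more compounds than are shown below. What is called first, only, known or untested is meant among the compounds shown, and "the series" means these compounds.

Of the compounds shown here, two have been measured in a functional assay on liver (Sus scrofa) for inhibition of squalene monooxygenase (Homo sapiens), using microsomes; a lower number here means a stronger inhibitor, a higher number a weaker inhibitor. Compound 1 `CCN(C/C=C/C#CC(C)(C)C)Cc1cccc(OC[Si](C)(C)c2ccc(C)cc2)c1` gives 120 nM in this assay. Compound 2 `CCN(C/C=C/C#CC(C)(C)C)Cc1cccc(OC[Si](C)(C)c2ccc(C(=O)C(F)(F)F)cc2)c1` gives 5000 nM in this assay, the higher of the two numbers, so among the measured compounds it is the weaker inhibitor. Among the measured compounds shown here, the single known step, a 42-fold higher number from compound 1 to compound 2 (1.62 log units; beyond the scatter), puts a (trifluoromethyl)carbonyl group in place of a methyl group on the aromatic ring attached to silicon.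

Compound 3 `CCN(C/C=C/C#CC(C)(C)C)Cc1cccc(OC[Si](C)(C)CCc2ccccc2)c1` is not yet measured. It differs from compound 2 in one place: phenethyl in place of 4-((trifluoromethyl)carbonyl)phenyl on a silicon. This change removes the whole ring that carries the (trifluoromethyl)carbonyl group, so the step from compound 1 to compound 2 is the only one that bears on it, and it runs the other way. Compound 3 is therefore expected to be a stronger inhibitor than compound 2 in this assay, with an expected step of a 25-fold lower number from compound 2 to compound 3 (1.40 log units; beyond the scatter), because a 42-fold higher number from compound 1 to compound 2 (1.62 log units; beyond the scatter) was a large loss that compound 3 no longer carries. Compound 3 is estimated at 200 nM in this assay, within a range from 60 nM to 700 nM.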

Compound 3, half-maximal inhibitory concentration: > 10000 nM
Compound 3 was reported as a limit (the forecaster's own chance of this, stated with the estimate: 2%); at least 50-fold (1.69 log units) between middle value and limit.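

In this assay the change on silicon from the 4-((trifluoromethyl)carbonyl)phenyl group to phenethyl gives an at least 2.0-fold higher number from compound 2 to compound 3 (0.30 log units; that floor lies within the scatter) and so removing that group does not win back the loss seen in compound 2, although no order between these two is established beyond the scatter. Set against the 4-methylphenyl group, phenethyl gives an at least 83-fold higher number from compound 1 to compound 3 (1.92 log units; beyond the scatter) and so the whole group on this silicon matters, not only what its ring carries, even though all three compounds hold a six-membered aromatic ring. The reading for compound 3 is a limit of the assay and not a number: the limit of > 10000 nM in this assay, at which 1 of the 3 values shown sits.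

On these data alone, how far compound 3 lies past its limit stays unknown, so both new steps are floors and their true sizes remain open. Also open, as far as these compounds go, is whether a plain phenyl or a benzyl group on this silicon, or a longer chain ending in a phenyl ring, would stay close to compound 1 or fall away as phenethyl does.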